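A few compounds are considered here, and "the series" means these few. Any claim that something is new, unique, unknown or untested is made for them only; others in the source may bear on it.

Compound 1 `CC(C)[C@@H]1CC[C@@H](C)C[C@@]12N(C)C(=O)[C@@H]1[C@H]3C(=O)NC(=O)[C@H]3ON12`: 38%
Compound 2 `CC(C)[C@@H]1CC[C@@H](C)C[C@@]12N(C)C(=O)[C@@H]1[C@H]3C(=O)N(c4ccccc4)C(=O)[C@H]3ON12`: 53.1%

In a functional assay, read by spectrophotometry, with a stated time of 2 h, tested at 2.5 mg/mL (on this read-out lower numbers stand for a weaker effect and higher numbers for a stronger effect at the one concentration tested), compound 1 gives 38%, the lower of the two measured numbers; compound 2 gives 53.1%. Compound 3 `Cc1cccc(N2C(=O)[C@H]3[C@H](ON4[C@@H]3C(=O)N(C)[C@@]43C[C@H](C)CC[C@H]3C(C)C)C2=O)c1` differs from compound 1 by 3-methylphenyl in place of hydrogen on an amide-type nitrogen in a ring. Among the compounds with values here, one measured step bears on this change: a number 15.1 percentage points higher from compound 1 to compound 2 (beyond the scatter), in which phenyl replaced hydrogen on the same amide-type nitrogen in a ring. Within the data shown here, no measured pair shows what the methyl of the 3-methylphenyl adds beyond plain phenyl, so the expectation rests on that single step. Among the measured compounds shown here, compound 3 is therefore expected to show a number 15 percentage points higher from compound 1 to compound 3 (beyond the scatter), a rise of about the size seen for compound 2, with wider uncertainty because the methyl-bearing ring has no measured counterpart. The estimate for compound 3 is 53%, within a range from 40% to 66%.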

Compound 3, a percentage reported as activity, at one concentration (the size of the read-out at that concentration, not a potency): 57.6%
Compound 3: the middle estimate sits 4.6 percentage points below what was measured, and the stated range covers the measured number.
By their numbers in this assay, from the lowest: compound 1; then compounds 2 and 3 (each within the scatter of the next).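

In this assay, a second aromatic group on the amide-type nitrogen in a ring also raises the number, a number 19.6 percentage points higher from compound 1 to compound 3 (beyond the scatter), so the rise seen with phenyl is not limited to that one group. Methyl in place of hydrogen on an aromatic carbon gives a number 4.5 percentage points higher from compound 2 to compound 3 (within the scatter), so the methyl of the 3-methylphenyl shows no separate contribution at this one concentration. Nothing available explains either step.

The compounds shown leave open whether the rise needs an aromatic ring at all, as a butyl chain or a cyclohexyl group on that nitrogen would test. They also leave open how the number would respond to a carboxylic acid or an amine on the phenyl ring.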